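A few compounds are considered here, and "the series" means these few. Any claim that something is new, unique, unknown or untested is made for them only; others in the source may bear on it.

Measured in a functional assay on MT4 cells (Homo sapiens) for inhibition; a higher number here means a weaker inhibitor, a lower number a stronger inhibitor:
- compound 1 `C=C1[C@@H](O)[C@H](n2cnc3c(N)ncnc32)O[C@@H]1CO`: 43000 nM
- compound 2 `C=C1[C@H](n2cnc3c(Cl)nc(N)nc32)O[C@H](CO)[C@H]1O`: 176000 nM

Compound 2 carries the higher of the two numbers, which makes it the weaker inhibitor, and its gap to compound 1 lies beyond the scatter. These two compounds do not differ in one place only, so they offer no single-change step to reason from.

Compound 3 `C=C1[C@H](n2cnc3c(SC)nc(N)nc32)O[C@H](CO)[C@H]1O` follows from compound 2 through methylsulfanyl in place of chloro on an aromatic carbon. Among the compounds with values here, no measured pair shows this change, so neither the size nor the direction of its effect in this assay has direct support, and no shift beyond the scatter is expected. The estimated 1.3-fold lower number from compound 2 to compound 3 (0.10 log units; within the scatter) therefore stays within the scatter. For compound 3 the expected value is 140000 nM, with an estimated range of 40000 nM to 400000 nM.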

Compound 3, half-maximal inhibitory concentration: > 500000 nM
Compound 3 gave a limit, no number (the forecaster's own chance of this, stated with the estimate: 30%); middle value at least 3.5-fold (0.55 log units) from the limit.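

In this assay compound 3 gives > 500000 nM, a limit of the assay and not a number. Methylsulfanyl in place of chloro on this aromatic carbon, next to the ring nitrogen, provides the first single-place comparison in the series, and it shows that the position is sensitive to this exchange, with the change running towards weaker inhibition: an at least 2.8-fold higher number from compound 2 to compound 3 (0.45 log units; beyond the scatter). This step has a direction but only a bound on its size, as it rests on a single limit: the limit of > 500000 nM in this assay, at which 1 of the 3 values shown sits.

Still open, from the compounds shown here alone, is whether an amine, a methoxy group or a longer alkylsulfanyl chain on this carbon would keep the number of compound 2 or move it further. Compound 1 differs from compound 2 in more than one place, so the contribution of chloro itself remains unresolved.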